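Ethoxymethyl to chloromethyl on the shared core

The source may report more compounds than this note shows. Statements on the series, on what has been measured and on what is new or still open speak of the compounds shown alone.

Measured in a functional assay on HFF cells (Homo sapiens) for cytotoxicity; a higher number here means a weaker inhibitor, a lower number a stronger inhibitor:
- compound 1 `COC[C@H]1O[C@@H](n2c(Cl)nc3cc(Cl)c(Cl)cc32)[C@H](OC(C)=O)[C@@H]1OC(C)=O`: 26000 nM
- compound 2 `CCOC[C@H]1OC(n2c(Cl)nc3cc(Cl)c(Cl)cc32)[C@H](O)[C@@H]1O`: 26000 nM

Compound 2 stands at 26000 nM, level with compound 1 within the scatter. Within the data shown here, the two compounds differ in more than one place, so this pair gives no single-change step. Among the measured compounds shown here, compound 3 `O[C@@H]1[C@@H](CCl)OC(n2c(Cl)nc3cc(Cl)c(Cl)cc32)[C@@H]1O` has no measurement yet. It departs from compound 2 in one place: chloro in place of ethoxy on a saturated chain carbon bound to a saturated ring carbon. In words, this is chloro in place of ethoxy on a saturated chain carbon bound to a saturated ring carbon.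

For the measured compounds named here, only two values are available, and no measured step covers this change. Since compound 1 at 26000 nM stays level with compound 2 despite its differences, no step beyond the scatter is expected in this assay, and no direction is favoured. The expected change is a 1.2-fold higher number from compound 2 to compound 3 (0.06 log units; within the scatter). The estimate for compound 3 is 30000 nM, with an expected range of 10000 nM to 90000 nM.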

Compound 3, half-maximal inhibitory concentration: 32000 nM
For compound 3 the middle estimate is 1.1-fold (0.03 log units) below the measured one, and the stated range covers the measured number.
By their numbers in this assay, from the lowest: compounds 1, 2 and 3 (each within the scatter of the next).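

Among these compounds, the first single-place reading comes from this position in this assay and is a 1.2-fold higher number from compound 2 to compound 3 (0.09 log units; within the scatter) for chloro in place of ethoxy on a saturated chain carbon bound to a saturated ring carbon. Ethoxy, with 3 heavy atoms and 1 hydrogen-bond acceptor, can thus give way to chloro, with 1 heavy atom and no hydrogen-bond acceptor, and the two compounds remain indistinguishable in this read-out. No measurement at hand offers an explanation for this result.

Going by these compounds, whether an amine, a carboxylic acid or a longer chain such as butoxymethyl at this place would also stay within the scatter of compound 2 remains open. Also open, on these data alone, is whether the same swap would read alike on the acetate esters of compound 1.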